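Lengthening the chain on a thiophene amide cytotoxin

The source may hold more compounds than are shown below. What is called first, only, known or untested is meant among the compounds shown, and "the series" means these compounds.

Three measured compounds share one core and differ only in the aromatic amide. Compound 1 `CCCCCCCCCCCCNC(=O)[C@@H](NC(=O)c1ccco1)[C@@H](C)O` gives 147000 nM in a functional assay on HepG2 cells (Homo sapiens) for cytotoxicity, read by MTT assay, with a stated time of 48 h; on this read-out lower numbers stand for stronger inhibition and higher numbers for weaker inhibition. Compound 2 `CCCCCCCCCCCCNC(=O)[C@@H](NC(=O)c1cccs1)[C@@H](C)O` gives 30100 nM in this assay. Compound 3 `CCCCCCCCCCCCNC(=O)[C@@H](NC(=O)c1cc2ccccc2n1C)[C@@H](C)O` reaches only the limit of this assay, > 200000 nM, so no number is known for it. For the measured compounds named here, compound 2 therefore stands lowest of the two numbers known, with compound 1 nearest a 4.9-fold lower number from compound 1 to compound 2 (0.69 log units; beyond the scatter). Swapping thiophene for the indole gives an at least 6.6-fold higher number from compound 2 to compound 3 (0.82 log units; beyond the scatter), and furan for indole gives an at least 1.3-fold higher number from compound 1 to compound 3 (0.13 log units; that floor lies within the scatter).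

Compound 4 `CCCCCCCCCCCCCCNC(=O)[C@@H](NC(=O)c1cccs1)[C@@H](C)O` keeps the thiophene amide of compound 2 and changes only the chain: ethyl in place of hydrogen on a saturated chain carbon, ten or more bonds along the chain from an amide-type nitrogen. Going by the values given here, none of the measured steps touches this chain; all three vary the aromatic ring instead, so no measured step bears directly on the change from compound 2 to compound 4. With no such evidence, compound 4 is expected to remain close to compound 2, with a step of a 1.0-fold lower number from compound 2 to compound 4 (0.00 log units; within the scatter) not beyond the scatter. The estimate for compound 4 is 30000 nM, expected to fall between 10000 nM and 90000 nM.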

Compound 4, half-maximal inhibitory concentration: 88400 nM
For compound 4 the middle estimate is 2.9-fold (0.47 log units) below the measured one; the range from low to high includes it.
By their numbers in this assay, from the lowest: compound 2; then compounds 4 and 1 (each within the scatter of the next). At a limit, above all of these: compound 3.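

For the compounds shown here, this is the first sign that the chain, and not only the aromatic amide, affects the result in this assay: with the thiophene amide held fixed, ethyl in place of hydrogen on a saturated chain carbon, ten or more bonds along the chain from an amide-type nitrogen, gives a 2.9-fold higher number from compound 2 to compound 4 (0.47 log units; beyond the scatter). So even this modest addition, made far along the chain, weakens the effect measurably and cannot be treated as a silent change. Nothing among the data shown explains why this step goes in this direction.

This single step cannot show a trend with chain length, so a shorter chain such as octyl, or a still longer one, remains an open case. Also open, from the compounds shown here alone, are whether ethyl has a similar effect on the furan amide of compound 1 and how an amine or a carboxylic acid at the end of the chain would behave.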